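The source may hold more compounds than are shown below. What is called first, only, known or untested is meant among the compounds shown, and "the series" means these compounds.

The series shares one core, seen in compound 1 `O=C(Nc1cccc(-n2cc(-c3ccncc3)c(-c3ccc(Cl)c(O)c3)n2)c1)Nc1ccc(Cl)c(Cl)c1`, which in a functional assay on SK-MEL-28 cells (Homo sapiens) for inhibition, read by sulforhodamine B assay, with a stated time of 48 h (a lower number here means a stronger inhibitor of growth, a higher number a weaker inhibitor of growth), gives 9850 nM. Compound 3 `O=C(Nc1cccc(-n2cc(-c3ccncc3)c(-c3ccc(Cl)c(O)c3)n2)c1)Nc1cc(C(F)(F)F)cc(C(F)(F)F)c1` carries a bis(trifluoromethyl)phenyl urea in place of the dichlorophenyl urea of compound 1, and in this assay compound 3 gives 1570 nM. Compound 2 `COc1cc(-c2nn(-c3cccc(NC(=O)c4cccc(C(F)(F)F)c4)c3)cc2-c2ccncc2)ccc1Cl` differs from both in carrying a methoxy group rather than a hydroxyl and an amide rather than a urea. In this assay compound 2 gives only a limit, > 50000 nM, and not a number. Compound 2 therefore sits at the limit of > 50000 nM in this assay, at which 1 of the 3 values shown sits.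

Compound 4 `COc1cc(-c2nn(-c3cccc(NC(=O)c4ccccc4)c3)cc2-c2ccncc2)ccc1Cl` is obtained from compound 2 by one change: hydrogen in place of trifluoromethyl on an aromatic carbon. Compound 2 itself is an inhibitor too weak to be measured, so the step from it cannot be known in size. The step that the limit leaves unreadable from compound 2 to compound 4 is expected to be none beyond the scatter, most likely leaving compound 4 at the limit as well. Compound 4 is expected to give about 60000 nM, in a range from 20000 nM to 150000 nM.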

Compound 4, concentration for total growth inhibition: > 100000 nM
Compound 4 ended at the assay's limit (the forecaster's own chance of this, stated with the estimate: 75%); at least 1.6-fold (0.22 log units) between middle value and limit.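

In this assay, among these compounds, compound 2 and compound 4 each give only a limit and not a number, so no step between them can be read. The compounds shown leave open what hydrogen in place of trifluoromethyl on an aromatic carbon does where both partners give numbers.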